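A Methylsulfonyl Group Enters Where Methyl Sat

A few compounds are considered here, and "the series" means these few. Any claim that something is new, unique, unknown or untested is made for them only; others in the source may bear on it.

Three pyrazoline compounds sharing one core have been tested in a functional assay on MCF7 cells (Homo sapiens) for antiproliferative activity, read by MTT assay, with a stated time of 72 h; on this read-out lower numbers stand for stronger inhibition and higher numbers for weaker inhibition. Compound 1, `Clc1ccc(C2CC(c3ccc(N4CCCCC4)cc3)=NN2c2nc(-c3ccccc3)cs2)cc1`, carries an unsubstituted phenyl on its thiazole; in this assay compound 1 gives 28400 nM. Compound 2, `Clc1ccc(-c2csc(N3N=C(c4ccc(N5CCCCC5)cc4)CC3c3ccc(Cl)cc3)n2)cc1`, adds a chloro to that phenyl, and its value is a limit of the assay: compound 2 gives > 100000 nM. Compound 3, `Cc1ccc(-c2csc(N3N=C(c4ccc(N5CCCCC5)cc4)CC3c3ccc(Cl)cc3)n2)cc1`, adds a methyl instead, and its value is likewise a limit: compound 3 gives > 100000 nM. Both additions therefore weakened activity: an at least 3.5-fold higher number from compound 1 to compound 2 (0.54 log units; beyond the scatter), and an at least 3.5-fold higher number from compound 1 to compound 3 (0.54 log units; beyond the scatter). Between the two substituted compounds the change is a step that the two limits leave unreadable from compound 2 to compound 3. Compound 3 thus stands at the limit of > 100000 nM in this assay, at which 2 of the 3 values shown sit, with no number of its own.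

Compound 4, `CS(=O)(=O)c1ccc(-c2csc(N3N=C(c4ccc(N5CCCCC5)cc4)CC3c3ccc(Cl)cc3)n2)cc1`, differs from compound 3 in one place: methylsulfonyl in place of methyl on an aromatic carbon. The bearing steps are those from the unsubstituted phenyl to the substituted ones, each at least modest and toward weaker inhibition, and two substituents of different kind both reached the limit. A third substituent at the same place is therefore expected to leave the number at or near the limit, with no readable step from compound 3: the expected step is a number no higher from compound 3 to compound 4 (the limit leaves the size open). For compound 4 the estimate is 100000 nM, within a range from 30000 nM to 300000 nM.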

Compound 4, half-maximal inhibitory concentration: > 100000 nM
Compound 4 ended at the assay's limit; the forecaster's own chance of this, stated with the estimate: 65%; the middle value lies on the limit itself.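

In this assay, methylsulfonyl on the phenyl also gives a weaker result than the unsubstituted compound, with an at least 3.5-fold higher number from compound 1 to compound 4 (0.54 log units; beyond the scatter). Among these compounds, this widens what the earlier compounds showed, since chloro and methyl were the only substituents tested at this place. Methylsulfonyl, with 4 heavy atoms and 2 hydrogen-bond acceptors against 1 heavy atom and 0 hydrogen-bond acceptors for methyl, differs far more in these counts, yet the outcome is the same, so all three substituents shown at this place go with weaker inhibition and no compound here goes against that. The steps among compound 2, compound 3 and compound 4 cannot be read, so no order among the three substituents can be given, because each of these compounds gives only a limit: the limit of > 100000 nM in this assay, at which 3 of the 4 values shown sit.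

Still open, as far as these compounds go, is whether any group at this place can match or improve on the hydrogen of compound 1, which gives 28400 nM; an amine, a hydroxyl or a carboxylic acid would each test this. Also open is how far above the limit the three substituted compounds truly lie, and whether their loss has any single cause, since the data shown offer no measurement that could separate one.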